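This account rests on a few compounds, and the source may have more. Where it says the series, first, only, none or still open, it means among the compounds named here.

Of the compounds shown here, three have been measured in an assay on isolated protein for inhibition of tyrosine-protein kinase receptor UFO (Homo sapiens), read by ELISA; on this read-out higher numbers stand for weaker inhibition and lower numbers for stronger inhibition. Compound 1 `Cn1cc(-c2ccc(NC(=O)c3cn(CC4CCOCC4)cc(-c4ccc(F)cc4)c3=O)cc2F)c2c(N)ncnc21` gives 0.8 nM. Compound 2 `Cn1cc(-c2ccc(NC(=O)c3cn(CC4CCOCC4)cc(-c4ccc(Cl)cc4)c3=O)cc2)c2c(N)ncnc21` gives 0.2 nM, and compound 3 `CN(C)CCn1cc(-c2ccc(NC(=O)c3cn(CC4CCOCC4)cc(-c4ccc(F)cc4)c3=O)cc2)c2c(N)ncnc21` gives 2.8 nM. Among these three numbers compound 1 holds the second highest place: compound 3 lies closest to it, with a number that is beyond the scatter and higher, while compound 2 lies furthest, with a number that is beyond the scatter and lower.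

Compound 4 `Cn1cc(-c2cc(F)c(NC(=O)c3cn(CC4CCOCC4)cc(-c4ccc(F)cc4)c3=O)cc2F)c2c(N)ncnc21` has not yet been measured. Compared with compound 1 it carries one change, (fluoro in place of hydrogen on an aromatic carbon). Within the data shown here, the new fluoro sits on the same six-membered aromatic ring of carbon only that already carries a fluoro group, and no measured pair shows this exact change, so its effect cannot be read directly from the measured compounds.

The step of a 1.6-fold higher number from compound 1 to compound 4 (0.21 log units; within the scatter) is expected to be small, toward a somewhat higher number and at most slightly beyond the usual scatter. Compound 4 is therefore expected to give about 1.3 nM, within a range from 0.4 nM to 4 nM.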

Compound 4, half-maximal inhibitory concentration: 0.5 nM
Beside the measured number, compound 4's estimate is 2.6-fold (0.41 log units) above it, and the stated range covers the measured number.
By their numbers in this assay, from the lowest: compound 2; then compounds 4 and 1 (each within the scatter of the next); then compound 3.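

In this assay, placing a fluoro on this aromatic carbon, ortho to a large group and para to the existing fluoro group, gives a 1.6-fold lower number from compound 1 to compound 4 (0.20 log units; within the scatter). Among these compounds, this is the first direct reading of a single change, and it shows that this carbon can take a fluoro in a ring already carrying one with no difference that can be told from the scatter of repeated measurements. Nothing measured here offers an explanation for this result.

From the compounds shown here alone, a single small atom says little about this carbon in general, so it stays open whether a chloro, a methoxy group or an amine at the same place would leave the number equally undisturbed. Going by these compounds, it is also open whether this fluoro would behave the same way in a ring without the first fluoro group.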